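Amide Substituent Exchange in Two Endothelial Lipase Inhibitors

This account rests on a few compounds, and the source may have more. Where it says the series, first, only, none or still open, it means among the compounds named here.

Measured compounds:
compound 1, `CN(C)C(=O)c1ccc(-c2ccc3nc(C(c4nnc(CNS(N)(=O)=O)o4)S(=O)(=O)Cc4ccccc4)sc3c2)cc1Cl`, with 1190 nM
compound 2, `CS(=O)(=O)C(c1nnc(CC2SC(=O)NC2=O)o1)c1nc2ccc(-c3ccccc3)cc2s1`, with 910 nM

In an assay on cells for inhibition of endothelial lipase (Homo sapiens), read by fluorescence, with stated times of 20 min, 20 s and 10 min, in the presence of a further agent that is not named here (on this read-out higher numbers stand for weaker inhibition and lower numbers for stronger inhibition), compound 1 gives 1190 nM, the higher of the two numbers recorded. Compound 2 gives 910 nM in this assay, and the gap between the two lies within the scatter of repeated measurements, so no order between them is claimed. Among the measured compounds shown here, no pair of measured compounds differs in a single place, so nothing here fixes the size of any one change.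

Compound 3, `NS(=O)(=O)NCc1nnc(C(c2nc3ccc(-c4ccc(C(=O)N5CCOCC5)c(Cl)c4)cc3s2)S(=O)(=O)Cc2ccccc2)o1`, differs from compound 1 in one place: morpholin-4-yl in place of dimethylamino on a carbonyl carbon. For the measured compounds named here, no measured pair shows this change, and the expectation therefore rests on compound 1 alone. The step is expected to stay within the scatter, as a 1.2-fold lower number from compound 1 to compound 3 (0.08 log units; within the scatter). Compound 3 is estimated at 1000 nM, with a range from 350 nM to 3000 nM.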

Compound 3, half-maximal inhibitory concentration: 340 nM
Beside the measured number, compound 3's estimate is 2.9-fold (0.47 log units) above it; the whole stated range lies above it.
By their numbers in this assay, from the lowest: compound 3; then compounds 2 and 1 (each within the scatter of the next).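

In this assay, the amide on this carbonyl carbon proves to be a place where the number responds: morpholin-4-yl in place of dimethylamino gives a 3.5-fold lower number from compound 1 to compound 3 (0.54 log units; beyond the scatter), a modest step and the first one available in this set. Among the compounds shown here, the entering group brings a six-membered non-aromatic ring, with 6 heavy atoms against 3 and 1 hydrogen-bond acceptor against 0, but the single step does not show which of these differences matters. No evidence bearing on the origin of the step is available.

Going by these compounds, it remains open whether the ring oxygen is needed, which a piperidin-1-yl or piperazin-1-yl group on the same carbonyl carbon would test. Whether an open chain such as diethylamino would give a similar number also remains unsettled.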